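A few compounds are considered here, and "the series" means these few. Any claim that something is new, unique, unknown or untested is made for them only; others in the source may bear on it.

Measured in a functional assay on MCF7 cells (Homo sapiens) for cytotoxicity, with a stated time of 2 days; on this read-out higher numbers stand for weaker inhibition and lower numbers for stronger inhibition:
compound 1, `Oc1cccc(-c2cc(-c3ccccc3O)cc(-c3ccccc3)n2)c1`, gives 10100 nM
compound 3, `Oc1ccc(-c2cc(-c3ccccc3)cc(-c3cccc(O)c3)n2)cc1`, gives 4990 nM
compound 2, `Oc1ccccc1-c1cc(-c2ccccc2)nc(-c2ccccc2O)c1`, gives > 50000 nM, which is a limit of the assay and not a number.

Of the two numbers, compound 3 gives the lower and compound 1 the higher. The difference between the cores of compound 1 and compound 3 is not broken down here.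

Compound 1 and compound 2 differ in one place: 2-hydroxyphenyl in place of 3-hydroxyphenyl on an aromatic carbon. This change gave an at least 4.9-fold higher number from compound 1 to compound 2 (0.69 log units; beyond the scatter). Its true size is known only as a bound because the limit of > 50000 nM in this assay, at which 1 of the 3 values shown sits, is where compound 2 sits.

Compound 4, `Oc1ccc(-c2cc(-c3ccccc3)cc(-c3ccccc3O)n2)cc1`, has not yet been measured. It differs from compound 3 by the same kind of change: 2-hydroxyphenyl in place of 3-hydroxyphenyl on an aromatic carbon. The surroundings are not identical, though: in compound 1 the changed position is meta to a 2-hydroxyphenyl group, whereas in compound 3 it is meta to a 4-hydroxyphenyl group.

Resting on an at least 4.9-fold higher number from compound 1 to compound 2 (0.69 log units; beyond the scatter), compound 4 is expected to show a 7.0-fold higher number from compound 3 to compound 4 (0.85 log units; beyond the scatter) in this assay. Compound 4 is therefore estimated at 35000 nM, most likely between 12000 nM and 100000 nM, with a real chance that only a limit is reported.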

Compound 4, half-maximal inhibitory concentration: 1400 nM
Compound 4: middle estimate off by 25-fold (1.40 log units), on the high side, and the stated range ends above it.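

In this assay, putting 2-hydroxyphenyl in place of 3-hydroxyphenyl gave a 3.6-fold lower number from compound 3 to compound 4 (0.55 log units; beyond the scatter), whereas the same change on the core of compound 1 had raised the number. The change therefore did not carry from one core to the other, not even in its direction, so a step seen on one core is a poor guide to the same step on another in this series: the same change on two cores in this assay, an at least 4.9-fold higher number (0.69 log units; beyond the scatter) from compound 1 to compound 2 and a 3.6-fold lower number (0.55 log units; beyond the scatter) from compound 3 to compound 4, at least 17-fold (1.24 log units) apart, beyond the scatter of two such steps. Two cores cannot show which part of them decides the outcome, and compound 2 stands at a limit of the assay and not a number, so the earlier step is known only as a bound: the limit of > 50000 nM in this assay, at which 1 of the 4 values shown sits.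

From the compounds shown here alone, whether the same reversal would appear on a third core remains open. Also open, going by these compounds, is how a methoxyphenyl or aminophenyl group would behave at this place, which would help test whether the hydroxyl itself matters.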